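A few compounds are considered here, and "the series" means these few. Any claim that something is new, unique, unknown or untested is made for them only; others in the source may bear on it.

Three compounds in the set carry a measured value. Compound 2 `CCNCc1cc(C)cc(Nc2nc3ccccc3n2Cc2ccc(C(F)(F)F)cc2)c1O` gives 98% in an ADME assay on microsomes from liver (Homo sapiens) for metabolic stability, read by LC-MS, with a stated time of 30 min, tested at 1 uM (on this read-out lower numbers stand for a less stable compound and higher numbers for a more stable compound), and stands highest of the three numbers, although the others come close: compound 3 `CCNCc1cc(Cl)cc(Nc2nc3ccccc3n2Cc2ccc(C(F)(F)F)cc2)c1O` gives 94%, a step of a number 4 percentage points lower from compound 2 to compound 3 (within the scatter), and compound 1 `Cc1cc(CNC(C)(C)C)c(O)c(Nc2nc3cc(F)c(F)cc3n2Cc2ccc(C(F)(F)F)cc2)c1` gives 90%, also within the scatter of compound 2. Among the measured compounds shown here, the only single-place step on record, chloro in place of methyl on an aromatic carbon, therefore changes nothing beyond the noise.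

Compound 4 `Cc1cc(CNC(C)(C)C)c(O)c(Nc2nc3ccccc3n2Cc2ccc(C(F)(F)F)cc2)c1` differs from compound 2 by tert-butyl in place of ethyl on an amine nitrogen. For the measured compounds named here, no measured step isolates this change. Compound 1 carries the same (tert-butyl)amino group but also differs in its ring substitution, so its value can only hint that the tert-butyl amine is compatible with a high number in this assay. With every measured step within the scatter, a step of no more than the scatter is expected from compound 2 to compound 4, namely a number 6 percentage points lower from compound 2 to compound 4 (within the scatter). For compound 4 the value is estimated at 92%, expected to lie between 78% and 100%.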

Compound 4, percent of the compound remaining: 99%
Compound 4: the middle estimate sits 7 percentage points below what was measured; low and high end bracket the measured number.
By their numbers in this assay, from the lowest: compounds 1, 3, 2 and 4 (each within the scatter of the next).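

In this assay, the exchange on an amine nitrogen is now seen on its own, with the rest of the structure held constant: tert-butyl in place of ethyl gives a number 1 percentage points higher from compound 2 to compound 4 (within the scatter). What compound 1 could only hint at can now be read directly, since this position carries tert-butyl, with 4 heavy atoms against 2 for ethyl, with no difference beyond the scatter. Nothing at hand explains this outcome.

Going by these compounds, it remains open whether the same holds for other groups on this nitrogen, such as a cyclohexyl ring, a longer chain or a carboxylic acid-bearing chain. Also open, on these data alone, is whether tert-butyl would behave alike with chloro in place of methyl on the aromatic carbon, the other change seen.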